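Pyridine Replaces Furan on the Hydrazone Arm

The compounds below may be only part of what the source reports. "The series", "measured", "known", "first", "only" and "open" are said of these compounds alone.

For the measured compounds named here, compound 3 `Cc1nc2cc(C(=O)N/N=C\c3ccco3)c([N+](=O)[O-])cc2[nH]1` is the only member of this small set with a number in a functional assay on MCF7 cells (Homo sapiens) for cytotoxicity, read by resazurin assay, with a stated time of 72 h; on this read-out lower numbers stand for stronger inhibition and higher numbers for weaker inhibition: compound 3 gives 81000 nM. Compound 1 `Cc1nc2cc(C(=O)NN)c([N+](=O)[O-])cc2[nH]1` reaches only the limit > 100000 nM in this assay, a limit rather than a number. Compound 2 `CC(C)=NNC(=O)c1ccc2[nH]c(C)nc2c1` likewise stops at the limit > 100000 nM. Going by the values given here, the one measured step, an at least 1.2-fold lower number from compound 1 to compound 3 (0.09 log units; that floor lies within the scatter), is read against (the limit of > 100000 nM in this assay, at which 2 of the 3 values shown sit). Compound 4 `Cc1nc2cc(C(=O)N/N=C\c3ccccn3)c([N+](=O)[O-])cc2[nH]1` differs from compound 3 by pyridin-2-yl in place of furan-2-yl on a carbon with a double bond to nitrogen. Among the compounds with values here, no measured step swaps one aromatic ring for another, and the single step available lies within the scatter, so no shift beyond the scatter is expected in this assay. Compound 4 is therefore expected to give 80000 nM, between 30000 nM and 200000 nM. The step of a 1.0-fold lower number from compound 3 to compound 4 (0.01 log units; within the scatter) that this estimate means is expected to stay within the scatter.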

Compound 4, half-maximal inhibitory concentration: > 100000 nM
Compound 4: only a limit was reported; the forecaster's own chance of this, stated with the estimate: 35%; at least 1.2-fold (0.09 log units) between middle value and limit.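

In this assay, from the compounds shown here alone, pyridin-2-yl in place of furan-2-yl on a carbon with a double bond to nitrogen gives an at least 1.2-fold higher number from compound 3 to compound 4 (0.09 log units; that floor lies within the scatter), so this ring swap yields no measurable gain and the true size of the step stays unknown. Furan-2-yl remains the only group at this place with a number, while compound 4 ends at a limit, as most of the set does: the limit of > 100000 nM in this assay, at which 3 of the 4 values shown sit. The remaining step cannot be read, as both of its values are limits.

Going by these compounds, whether phenyl or thiophen-2-yl at this place would give a number in this assay stays open.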